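Chloro for bromo on the styryl sulfone aryl ring

The source may report more compounds than this note shows. Statements on the series, on what has been measured and on what is new or still open speak of the compounds shown alone.

- compound 1 `O=S(=O)(/C=C/c1ccc(Cl)cc1)Cc1ccc(Nc2ncnc3ccccc23)cc1`: > 100000 nM (a limit)
- compound 2 `O=S(=O)(/C=C/c1ccc(Br)cc1)Cc1ccc(Nc2ncnc3ccc(Br)cc23)cc1`: 2000 nM

All values come from a functional assay on OVCAR-8 cells (Homo sapiens); on this read-out lower numbers stand for stronger inhibition of growth and higher numbers for weaker inhibition of growth. In this assay, for the measured compounds named here, compound 2 gives 2000 nM, the only true number so far. Compound 1 reads > 100000 nM, which is a limit of the assay and not a number.

The next compound is compound 3 `O=S(=O)(/C=C/c1ccc(Cl)cc1)Cc1ccc(Nc2ncnc3ccc(Br)cc23)cc1`. It keeps everything in compound 2 except one substituent, with chloro in place of bromo on an aromatic carbon of a six-membered aromatic ring of carbon only, para to a large group: chloro in place of bromo on an aromatic carbon. The same difference reads as 4-bromophenyl to 4-chlorophenyl.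

Going by the values given here, no measured step shows this exchange, so there is no direct precedent for its size. In this assay no change beyond the scatter is expected, and no direction is favoured. Among the compounds with values here, the expectation is anchored on compound 2 at 2000 nM, the only measured compound that differs from compound 3 in one place. The expected step is a 1.3-fold higher number from compound 2 to compound 3 (0.10 log units; within the scatter). For compound 3 the estimated value is 2500 nM, with an expected range of 900 nM to 7000 nM.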

Compound 3, concentration for 50% growth inhibition: 3000 nM
For compound 3 the middle estimate is 1.2-fold (0.08 log units) below the measured one; low and high end bracket the measured number.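

In this assay, the exchange of 4-bromophenyl for 4-chlorophenyl leaves the read-out within the usual scatter, a 1.5-fold higher number from compound 2 to compound 3 (0.18 log units; within the scatter), so on this aromatic carbon, para to a large group, these two halogens cannot be told apart. The other bromo carries far more weight, since with the chloro held constant, bromo in place of hydrogen on an aromatic carbon gives an at least 33-fold lower number from compound 1 to compound 3 (1.52 log units; beyond the scatter). Compound 1 gives > 100000 nM, which is a limit of the assay and not a number, so this step has no fixed upper size: the limit of > 100000 nM in this assay, at which 1 of the 3 values shown sits.

As far as these compounds go, only two halogens appear at the para position of the aryl ring, so it stays open whether hydrogen, fluoro, methoxy or an amine there would hold growth inhibition at the level of compound 2 and compound 3. The bromo that compound 2 and compound 3 share with each other is compared only with hydrogen, which leaves open what chloro, methyl or a nitrile would do on that aromatic carbon.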